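A few compounds are considered here, and "the series" means these few. Any claim that something is new, unique, unknown or untested is made for them only; others in the source may bear on it.

Working notes on the series. Among the measured compounds shown here, in an ADME assay on microsomes from liver (Homo sapiens) for metabolic stability, with a stated time of 10 min (on this read-out lower numbers stand for a less stable compound and higher numbers for a more stable compound), compound 1 `C[C@]1(C(=O)O)CC[C@H](C(=O)N2CC[C@](c3ccc(C(F)(C(F)(F)F)C(F)(F)F)cc3)(S(=O)(=O)c3ccc(F)cc3)C2)CC1` gives 97% and compound 2 `O=C([C@H]1CC[C@H](CO)CC1)N1CC[C@](c2ccc(C(F)(C(F)(F)F)C(F)(F)F)cc2)(S(=O)(=O)c2ccc(F)cc2)C1` gives 75%, so compound 2 holds the lower of the two numbers so far. Compound 3 `O=C(N1CC[C@](c2ccc(C(F)(C(F)(F)F)C(F)(F)F)cc2)(S(=O)(=O)c2ccc(F)cc2)C1)C1(F)CCS(=O)(=O)CC1` is the next to be read. The structural change is 4-fluoro-1,1-dioxothian-4-yl in place of 4-(hydroxymethyl)cyclohexyl on a carbonyl carbon, with 4-fluoro-1,1-dioxothian-4-yl in place of 4-(hydroxymethyl)cyclohexyl on a carbonyl carbon. For the measured compounds named here, one measured step bears on it, at the same place: a number 22 percentage points lower from compound 1 to compound 2 (beyond the scatter), modest and beyond the scatter, where 4-(hydroxymethyl)cyclohexyl replaced 4-carboxy-4-methylcyclohexyl. Going by the values given here, that single step is thin support, and no measured compound carries the entering group. With the group of compound 2 leaving, a modest rise of similar size or smaller is expected in this assay. The estimated change is a number 13 percentage points higher from compound 2 to compound 3 (beyond the scatter). For compound 3 the estimated value is 88%, with a range of 72% to 99%.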

Compound 3, percent of the compound remaining: 100%
The estimate for compound 3 lay 12 percentage points below the measured number; the whole stated range lies below it.
By their numbers in this assay, from the lowest: compound 2; then compounds 1 and 3 (each within the scatter of the next).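

With a number 25 percentage points higher from compound 2 to compound 3 (beyond the scatter) in this assay, the lower number of compound 2 proves not to be a general result of losing the 4-carboxy-4-methylcyclohexyl group: the 4-fluoro-1,1-dioxothian-4-yl group on the same carbonyl carbon carries no carboxylic acid, yet the number is higher than with 4-(hydroxymethyl)cyclohexyl. The step of a number 3 percentage points higher from compound 1 to compound 3 (within the scatter) leaves these two groups indistinguishable on this read-out, so two quite different groups at this place are now tied. Nothing available explains why either group differs from 4-(hydroxymethyl)cyclohexyl.

The compounds shown leave open whether the fluorine or the ring sulfone accounts for the step from 4-(hydroxymethyl)cyclohexyl, which a 1,1-dioxothian-4-yl group without fluorine would separate. Also open, going by these compounds, is how an amine on the same ring would read at this place.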